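Tetrazole aryl swap: pyridin-2-yl to 4-methylphenyl

This account rests on a few compounds, and the source may have more. Where it says the series, first, only, none or still open, it means among the compounds named here.

Two compounds of the series carry the shared core of compound 2 `Cc1cc(NC(=O)Cn2nnc(-c3ccccn3)n2)n(C2CCCCC2)n1` and compound 1 `Cc1cc(NC(=O)Cn2nnc(-c3ccccc3)n2)n(C2CCC(C)(C)CC2)n1`, which differ in the aryl group on the tetrazole and in the ring on the pyrazole nitrogen. For the measured compounds named here, in an assay on HEK293 cells for activation of Kir3.1/Kir3.2 (Homo sapiens), read by thallium flux (a higher number here means that more compound is needed for the effect, a lower number that less compound is needed), compound 2 gives 14600 nM, the only full number so far. For compound 1 the read-out is a limit of the assay, > 221 nM, and it is recorded as such (the limit of > 221 nM in this assay, at which 1 of the 2 values shown sits). Going by the values given here, because the two compounds differ in more than one place, no single step can be drawn between them; their two values show only that compound 1 sits at a limit and compound 2 at a measurable weak value.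

Compound 3 `Cc1ccc(-c2nnn(CC(=O)Nc3cc(C)nn3C3CCCCC3)n2)cc1` is to be measured. It differs from compound 2 by 4-methylphenyl in place of pyridin-2-yl on an aromatic carbon

Among the compounds with values here, no measured step fits this change, so the expectation rests on compound 2 alone and the size is uncertain. Compound 3 is expected at 9000 nM, with a range of 2500 nM to 30000 nM. The expected step of a 1.6-fold lower number from compound 2 to compound 3 (0.21 log units; within the scatter) is small and of unclear direction, possibly within the scatter.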

Compound 3, half-maximal effective concentration: 111 nM
For compound 3 the middle estimate is 81-fold (1.91 log units) above the measured one, outside the stated range (below it).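

For the compounds shown here, the aryl group on the tetrazole is the first position with a step that can be read: in this assay, 4-methylphenyl in place of pyridin-2-yl gives a 130-fold lower number from compound 2 to compound 3 (2.12 log units; beyond the scatter), so this place on an aromatic carbon is not a silent one. The step replaces a six-membered aromatic ring with 1 hetero atom and 1 hydrogen-bond acceptor by a ring of carbon only that carries a methyl, and with that change far less compound is needed for the effect. No measured property of either group accompanies these values, so the size of the step stands without an explanation.

The change combines two edits, the loss of the ring nitrogen and the gain of the methyl, and compound 1, with plain phenyl but a different ring on the pyrazole nitrogen, cannot separate them, since its > 221 nM is a limit of the assay. Which edit carries the step stays open, as does the outcome with a chlorine, a methoxy group or a carboxylic acid in place of that methyl.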